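A few compounds are considered here, and "the series" means these few. Any claim that something is new, unique, unknown or untested is made for them only; others in the source may bear on it.

Compound 1 `CCCCC(CCO)n1cnc2c(Cl)ncnc21` is examined in a functional assay on HCT-116 cells (Homo sapiens) for antiproliferative activity, read by MTT assay, with a stated time of 48 h; a higher number here means a weaker inhibitor, a lower number a stronger inhibitor. In this assay compound 1 reaches only the limit of the assay, > 50000 nM, and gives no number. Compound 2 `CCCCC(CCO)n1cnc2c(Cl)nc(Cl)nc21` differs from compound 1 by chloro in place of hydrogen on an aromatic carbon. In this assay compound 2 gives 15500 nM, so the step of an at least 3.2-fold lower number from compound 1 to compound 2 (0.50 log units; beyond the scatter) is a gain whose full size is not known because the limit of > 50000 nM in this assay, at which 2 of the 3 values shown sit, fixes where compound 1 sits. Compound 3 `CCCCCC(CCO)n1cnc2c(N)ncnc21` carries a different core; how its core differs from that of compound 1 is not broken down here. In this assay compound 3 also reaches only the limit of the assay, > 50000 nM. Compound 4 `CCCCCC(CCO)n1cnc2c(N)nc(Cl)nc21` differs from compound 3 by chloro in place of hydrogen on an aromatic carbon. This is the same kind of change as that from compound 1 to compound 2, except that the entering chloro is meta to an amino group in compound 4, whereas in compound 2 it is meta to a chloro group. Resting on an at least 3.2-fold lower number from compound 1 to compound 2 (0.50 log units; beyond the scatter), the expected step is an at least 1.6-fold lower number from compound 3 to compound 4 (0.22 log units; that floor lies within the scatter). Compound 3 gives only a limit, so this expectation starts from an uncertain point. Compound 4 is therefore expected to give about 30000 nM, within a range from 8000 nM to 100000 nM, with a real chance that it too reaches only the limit.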

Compound 4, half-maximal inhibitory concentration: > 50000 nM
Compound 4: only a limit was reported; the forecaster's own chance of this, stated with the estimate: 55%; middle value at least 1.6-fold (0.22 log units) from the limit.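

In this assay, compound 3 and compound 4 both reach only a limit, so no step between them can be read: the limit of > 50000 nM in this assay, at which 3 of the 4 values shown sit.

The compounds shown leave open whether chloro in place of hydrogen on an aromatic carbon lowers the number when going to compound 4, as the same change does in going to compound 2.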